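The source may hold more compounds than are shown below. What is called first, only, known or untested is meant among the compounds shown, and "the series" means these compounds.

Of the compounds shown here, three sharing one core have been tested in a functional assay on HeLa cells (Homo sapiens) for cytotoxicity, read by MTT assay, with a stated time of 48 h; a lower number here means a stronger inhibitor, a higher number a weaker inhibitor. Compound 1, `O=c1ccoc2cc(OCc3cn(Cc4ccc([N+](=O)[O-])cc4)nn3)ccc12`, gives 25700 nM. Compound 2, `O=c1ccoc2cc(OCc3cn(Cc4ccccc4Br)nn3)ccc12`, gives 14500 nM. For compound 3, `O=c1ccoc2cc(OCc3cn(Cc4ccccc4Cl)nn3)ccc12`, the result is > 100000 nM, which is a limit of the assay rather than a number. Among the numbers shown compound 2 stands lowest, with compound 1 nearest to it, and the step of a 1.8-fold lower number from compound 1 to compound 2 (0.25 log units; within the scatter) is within the scatter. The step of an at least 6.8-fold higher number from compound 2 to compound 3 (0.83 log units; beyond the scatter) is beyond the scatter, as is an at least 3.8-fold higher number from compound 1 to compound 3 (0.59 log units; beyond the scatter); both rest on the limit (the limit of > 100000 nM in this assay, at which 1 of the 3 values shown sits).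

Compound 4, `O=c1ccoc2cc(OCc3cn(Cc4ccccc4F)nn3)ccc12`, has not yet been measured. It differs from compound 2 by fluoro in place of bromo on an aromatic carbon. Within the data shown here, the only measured step that bears on this change is an at least 6.8-fold higher number from compound 2 to compound 3 (0.83 log units; beyond the scatter), in which chloro in place of bromo on an aromatic carbon carried the number up to the limit. A step in the same direction is therefore expected in this assay for compound 4, and the estimated step of a 4.1-fold higher number from compound 2 to compound 4 (0.62 log units; beyond the scatter) is taken to lie beyond the scatter. Compound 4 is expected to give about 60000 nM, within a range from 20000 nM to 200000 nM, with a fair chance that only a limit is recorded.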

Compound 4, half-maximal inhibitory concentration: > 100000 nM
Compound 4 was reported as a limit; the forecaster's own chance of this, stated with the estimate: 45%; at least 1.6-fold (0.22 log units) between middle value and limit.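

In this assay compound 4 gives > 100000 nM, which is a limit of the assay and not a number. The change from bromo to fluoro on this aromatic carbon, ortho to a large group, is a second case, after the chloro of compound 3, in which replacing bromo ends at the limit, with an at least 6.8-fold higher number from compound 2 to compound 4 (0.83 log units; beyond the scatter) and an at least 3.8-fold higher number from compound 1 to compound 4 (0.59 log units; beyond the scatter), so that of the three halogens shown on this carbon only the bromo of compound 2 gives a number. The step from compound 3 to compound 4 cannot be read, and compound 3 and compound 4 now both rest on the limit: the limit of > 100000 nM in this assay, at which 2 of the 4 values shown sit.

On these data alone, how far compound 3 and compound 4 actually lie past the limit remains open, and with it the order of chloro and fluoro on this carbon. Also open, as far as these compounds go, is whether a group that is not a halogen on this same carbon, such as methoxy, an amine or a carboxylic acid, would give a number, and whether bromo would keep its number on another carbon of the ring.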